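The compounds below may be only part of what the source reports. "The series", "measured", "known", "first", "only" and "open" are said of these compounds alone.

In a physicochemical assay for solubility, at pH 7.4 (on this read-out lower numbers stand for lower solubility and higher numbers for higher solubility), the measured compounds read:

- compound 1 `CN(C)C1(C)CN(c2c(F)cc3c(=O)c(C(=O)O)cn(C4CC4)c3c2F)C1`: 23.6 ug/mL
- compound 2 `CNC1(C)CN(c2c(F)cc3c(=O)c(C(=O)O)cn(C4CC4)c3c2F)C1`: 0.5 ug/mL
- compound 3 `C[C@H]1N(c2c(F)cc3c(=O)c(C(=O)O)cn(C4CC4)c3c2F)C[C@]1(C)N`: 3.3 ug/mL

Compound 3 at 3.3 ug/mL stands in the middle of these three numbers. Compound 4 `CN[C@H]1CN(c2c(F)cc3c(=O)c(C(=O)O)cn(C4CC4)c3c2F)[C@@H]1C` has the same atoms as compound 3, joined differently: a group of 7 heavy atoms (5 carbon, 2 nitrogen; one four-membered non-aromatic ring with 1 hetero atom) in place of a group of 7 heavy atoms (5 carbon, 2 nitrogen; one four-membered non-aromatic ring with 1 hetero atom), on an aromatic carbon. The nearest guides are two modest steps, a 6.6-fold higher number from compound 2 to compound 3 (0.82 log units; beyond the scatter) and a 7.2-fold lower number from compound 1 to compound 3 (0.85 log units; beyond the scatter), which also involve this group. The large 47-fold lower number from compound 1 to compound 2 (1.67 log units; beyond the scatter) shows that hydrogen in place of methyl on an amine nitrogen can matter in this series. These steps do not settle a direction, so no step beyond the scatter is expected. The estimate means a 1.1-fold lower number from compound 3 to compound 4 (0.04 log units; within the scatter) as the expected step. The estimated value for compound 4 is 3 ug/mL (0.7 ug/mL to 14 ug/mL).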

Compound 4, solubility: 13.1 ug/mL
Estimate against measurement, compound 4: 4.4-fold (0.64 log units) below; measured number inside the range.
By their numbers in this assay, from the lowest: compound 2; then compound 3; then compounds 4 and 1 (each within the scatter of the next).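

In this assay the arrangement of the same atoms at this position matters on its own: a 4.0-fold higher number from compound 3 to compound 4 (0.60 log units; beyond the scatter) and a 26-fold higher number from compound 2 to compound 4 (1.42 log units; beyond the scatter) are both steps between groups of identical atom content. Size alone does not set the number either, since compound 1 carries one more carbon in its group, yet a 1.8-fold lower number from compound 1 to compound 4 (0.26 log units; within the scatter) leaves the two within the usual scatter. No measurement shown here explains these differences. Still open, as far as these compounds go, is whether such swings persist with an ethyl group on the amine nitrogen or with a larger pyrrolidine ring in place of the four-membered one.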